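The compounds below may be only part of what the source reports. "The series", "measured", "known", "first", "only" and "open" are said of these compounds alone.

Three compounds have been tested in a functional assay on the whole organism for antagonist activity, with Mus musculus as the target; on this read-out lower numbers stand for an effect already at smaller amounts and higher numbers for an effect only at larger amounts of compound:

compound 1 `CC(C#CCn1ccnc1)N1CCCC1=O` gives 45 mg/kg;
compound 2 `Cc1cncn1CC#CC(C)N1CCCC1=O` gives 25.4 mg/kg;
compound 3 `CCOC(=O)N(C)C(C)C#CCn1ccnc1` gives > 100 mg/kg, which is a limit of the assay and not a number.

Compound 1 and compound 2 share one core and differ only by methyl in place of hydrogen on an aromatic carbon. That change made a 1.8-fold lower number from compound 1 to compound 2 (0.25 log units; within the scatter), so the two values sit within the usual scatter of each other. Compound 3 is built on another core; the difference between the two cores is not broken down here. For compound 3 the assay gave only a limit, as seen in the limit of > 100 mg/kg in this assay, at which 1 of the 3 values shown sits.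

Compound 4 `CCOC(=O)N(C)C(C)C#CCn1cncc1C` has not yet been measured in this assay. It differs from compound 3 by methyl in place of hydrogen on an aromatic carbon, the same change that was made between compound 1 and compound 2. A step of about the same small size is expected, a number no higher from compound 3 to compound 4 (the limit leaves the size open), resting on a 1.8-fold lower number from compound 1 to compound 2 (0.25 log units; within the scatter). Because the limit of > 100 mg/kg in this assay, at which 1 of the 3 values shown sits, holds for compound 3, compound 4 is expected to land near or past that limit, estimated at 100 mg/kg, between 45 mg/kg and 300 mg/kg.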

Compound 4, dose for half-maximal effect: 30 mg/kg
Estimate against measurement, compound 4: 3.3-fold (0.52 log units) above; the measured number lies below the stated range.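

In this assay, the change from 1H-imidazol-1-yl to 5-methyl-1H-imidazol-1-yl gave an at least 3.3-fold lower number from compound 3 to compound 4 (0.52 log units; beyond the scatter), so on the core of compound 3 this single methyl goes with a shift that the usual scatter does not cover. The same change has now been read on two cores, and only on the core of compound 3 does it clear the scatter: the same change on two cores in this assay, a 1.8-fold lower number (0.25 log units; within the scatter) from compound 1 to compound 2 and an at least 3.3-fold lower number (0.52 log units; beyond the scatter) from compound 3 to compound 4; the limit leaves it open whether they differ. Compound 3 gives > 100 mg/kg, which is a limit and not a number, so these pairs show neither that the methyl counts for more on one core than on the other nor that it counts the same on both.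

The compounds shown leave open whether a group other than methyl on this ring carbon, such as ethyl or chlorine, would move the number as well. They also leave open what the methyl does on a third core, for instance one that carries a plain amine at the place where compound 1 and compound 3 differ.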